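Swapping a Phenyl for Benzylamino on the Carbonyl Carbon

The source may report more compounds than this note shows. Statements on the series, on what has been measured and on what is new or still open speak of the compounds shown alone.

Of the compounds shown here, three sharing one core have been tested in an assay on nucleic acid for inhibition of Nucleic Acid, read by fluorescence, tested at 100 uM; on this read-out higher numbers stand for more inhibition at the one concentration tested (going by the name of the read-out) and lower numbers for less inhibition. Compound 1 `CN(CCCc1ccccc1)Cc1cn(CC(O)COC(=O)NCc2ccccc2)nn1` gives 79%, compound 2 `CCCCNC(=O)OCC(O)Cn1cc(CN(C)CCC(C)C)nn1` gives 24%, and compound 3 `CC(C)CCN(C)Cc1cn(CC(O)COC(=O)c2ccccc2)nn1` gives 0%. On these numbers compound 3 stands lowest, with compound 2 the nearest to it and compound 1 the furthest away, both gaps beyond the usual scatter.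

The new compound 4 `CC(C)CCN(C)Cc1cn(CC(O)COC(=O)NCc2ccccc2)nn1` differs from compound 3 in one place: benzylamino in place of phenyl on a carbonyl carbon. Among the measured compounds shown here, the only measured step that touches the same carbonyl carbon runs the other way, where a number 24 percentage points lower from compound 2 to compound 3 (beyond the scatter) when phenyl replaced butylamino. Putting a nitrogen-linked group back onto that carbonyl carbon should therefore be expected to undo that loss, and compound 1, which also carries benzylamino on its carbonyl carbon, gives the highest reading of the three, though it differs from compound 4 elsewhere as well.

For compound 4 in this assay a rise is expected, a number 40 percentage points higher from compound 3 to compound 4 (beyond the scatter), giving an estimated 40% with a likely range from 15% to 70%.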

Compound 4, a percentage reported as inhibition, at one concentration (the size of the read-out at that concentration, not a potency): 26%
For compound 4 the middle estimate is 14 percentage points above the measured one, and the stated range covers the measured number.
By their numbers in this assay, from the lowest: compound 3; then compounds 2 and 4 (each within the scatter of the next); then compound 1.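

In this assay there is a number 26 percentage points higher from compound 3 to compound 4 (beyond the scatter) with benzylamino in place of phenyl on the carbonyl carbon, so the low reading of compound 3 now stands against two different nitrogen-linked groups, not butylamino alone. The two nitrogen-linked groups themselves cannot be told apart, with a number 2 percentage points higher from compound 2 to compound 4 (within the scatter) for phenyl in place of propyl on a saturated chain carbon bound to an amide-type nitrogen, so the extra ring at this end brings no visible gain here. The largest step lies elsewhere in the molecule, with a number 53 percentage points lower from compound 1 to compound 4 (beyond the scatter) for isopropyl in place of benzyl on a saturated chain carbon, two bonds along the chain from an amine nitrogen, so benzylamino alone does not bring the high reading of compound 1.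

Nothing at hand gives a reason for any of these differences. Still open, going by these compounds, is how a hexylamino or dimethylamino group would read on the carbonyl carbon, and whether butylamino and benzylamino would stay level on the core of compound 1.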